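Chloro for Trifluoromethyl on the Triazole Aryl Arm

The source may report more compounds than this note shows. Statements on the series, on what has been measured and on what is new or still open speak of the compounds shown alone.

Compound 1 `C=C1C[C@]23C[C@@]1(O)CC[C@H]2c1ccc(O)c(C)c1[C@@H]3Cn1cc(-c2ccc(C(F)(F)F)cc2)nn1` was tested in a functional assay on A549 cells (Homo sapiens) for cytotoxicity, read by MTT assay, with a stated time of 4 days (a higher number here means a weaker inhibitor, a lower number a stronger inhibitor), and gives 10400 nM, the higher of the two numbers seen so far. Compound 2 `C=C1C[C@]23C[C@@]1(O)CC[C@H]2c1cc(Br)c(O)c(C)c1[C@@H]3Cn1cc(-c2ccc(C(F)(F)F)cc2)nn1` carries bromo in place of hydrogen on an aromatic carbon of the phenol ring and gives 9280 nM; the step of a 1.1-fold lower number from compound 1 to compound 2 (0.05 log units; within the scatter) stays within the scatter. Compound 3 `C=C1C[C@]23C[C@@]1(O)CC[C@H]2c1ccc(OS(=O)(=O)c2ccc(C)cc2)c(C)c1[C@@H]3Cn1cc(-c2ccc(C(F)(F)F)cc2)nn1`, with (4-methylphenyl)sulfonyl on the phenolic oxygen, reaches only a limit of the assay, > 20000 nM, as recorded in the limit of > 20000 nM in this assay, at which 1 of the 3 values shown sits. Its step of an at least 1.9-fold higher number from compound 1 to compound 3 (0.28 log units; that floor lies within the scatter) has a floor that also lies within the scatter.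

Compound 4 `C=C1C[C@]23C[C@@]1(O)CC[C@H]2c1ccc(O)c(C)c1[C@@H]3Cn1cc(-c2ccc(Cl)cc2)nn1` changes a different part of the molecule: chloro in place of trifluoromethyl on an aromatic carbon. Among the compounds with values here, neither measured step touches this aryl ring, so no measured step bears directly on it, and the two steps that exist both stayed within the scatter. Compound 4 is therefore expected to differ from compound 1 by a step of about no change at the digits printed from compound 1 to compound 4 (within the scatter), that is, none beyond the scatter. Compound 4 is estimated at 10400 nM, within a range from 4000 nM to 25000 nM.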

Compound 4, half-maximal inhibitory concentration: > 20000 nM
Compound 4: no number, only a limit (the forecaster's own chance of this, stated with the estimate: 20%); middle value at least 1.9-fold (0.28 log units) from the limit.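

In this assay compound 4 gives > 20000 nM, which is a limit of the assay and not a number. The step of an at least 1.9-fold higher number from compound 1 to compound 4 (0.28 log units; that floor lies within the scatter) is the first one shown on the 4-(trifluoromethyl)phenyl arm rather than on the phenol ring, and it shows that 4-chlorophenyl at this place does not return a number within the range of the assay, so this arm can be changed with the read-out lost, which the bromo step on the phenol ring did not show. At this ceiling compound 4 now stands with compound 3, the other compound without a number, so the set holds two separate changes that end the same way: the limit of > 20000 nM in this assay, at which 2 of the 4 values shown sit.

As far as these compounds go, since only a floor is available and it lies within the scatter, the true size of the step from trifluoromethyl to chloro stays unknown, and it remains open whether compound 4 truly differs from compound 1. Also open, from the compounds shown here alone, is whether a different group on this aromatic carbon, such as an amine, a methoxy group or a carboxylic acid, would give a number below the limit.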